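The source may report more compounds than this note shows. Statements on the series, on what has been measured and on what is new or still open speak of the compounds shown alone.

Working notes on the series. Among the compounds with values here, in a functional assay for inhibition of nuclear factor NF-kappa-B complex (Homo sapiens) (on this read-out lower numbers stand for stronger inhibition and higher numbers for weaker inhibition), compound 3 `CCCCNC(=O)C1=Cc2ccc(OC)cc2OC1c1cc(OC)c(OC)c(OC)c1` gives 25500 nM, the highest of the three numbers so far, although its gaps to the other two stay within the scatter. Compound 1 `COc1ccc2c(c1)OC(c1cc(OC)c(OC)c(OC)c1)C(C(=O)OCCc1ccccc1)=C2` gives 16200 nM, and compound 2 `COC(=O)C1=Cc2ccc(OC)cc2OC1c1cc(OC)c(OC)c(OC)c1` gives 13800 nM. Every measured step exchanges the group on the carbonyl carbon: a 1.2-fold lower number from compound 1 to compound 2 (0.07 log units; within the scatter), a 1.6-fold higher number from compound 1 to compound 3 (0.20 log units; within the scatter), a 1.8-fold higher number from compound 2 to compound 3 (0.27 log units; within the scatter). None of them reached beyond the scatter. Compound 4 `COc1ccc2c(c1)OC(c1cc(OC)c(OC)c(OC)c1)C=C2` goes further and takes the whole branch away: hydrogen in place of butylcarbamoyl on a double-bonded ring carbon. Within the data shown here, no measured step removes the carbonyl altogether, so this change lies outside what the three steps cover. With every change on the carbonyl carbon held within the scatter, the read-out is expected to move little here as well, but the wider range reflects the untested removal. For compound 4 the estimate is 22000 nM, with a range from 8000 nM to 60000 nM. The step expected is a 1.2-fold lower number from compound 3 to compound 4 (0.06 log units; within the scatter), most likely within the scatter.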

Compound 4, half-maximal inhibitory concentration: 17700 nM
Beside the measured number, compound 4's estimate is 1.2-fold (0.09 log units) above it; the measured number falls inside the stated range.
By their numbers in this assay, from the lowest: compounds 2, 1, 4 and 3 (each within the scatter of the next).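

In this assay, hydrogen on the double-bonded ring carbon reads within the scatter of all three carbonyl-bearing groups: butylcarbamoyl (a 1.4-fold lower number from compound 3 to compound 4 (0.16 log units; within the scatter)), methoxycarbonyl (a 1.3-fold higher number from compound 2 to compound 4 (0.11 log units; within the scatter)) and phenethyloxycarbonyl (a 1.1-fold higher number from compound 1 to compound 4 (0.04 log units; within the scatter)). The earlier steps only exchanged the group on the carbonyl carbon, whereas these show that removing the whole branch, carbonyl included, also leaves the read-out within the scatter, so none of the three branches is shown to contribute measurably at this position. No evidence at hand bears on this result.

Going by these compounds, whether any group on this ring carbon can move the number beyond the scatter stays open, for example a carboxylic acid or an aminomethyl group. On these data alone, whether changes elsewhere on the shared core would do so also stays open.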